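Shifting One Hydroxyl Around a Shared Core

The source may hold more compounds than are shown below. What is called first, only, known or untested is meant among the compounds shown, and "the series" means these compounds.

Of the compounds shown here, two have been measured so far. Compound 1 `Oc1ccc(-c2cc(-c3ccc(O)cc3)nc(-c3ccc(O)cc3)c2)cc1` carries three 4-hydroxyphenyl groups on the shared core, and in a functional assay on DU-145 cells (Homo sapiens) for cytotoxicity, read by CCK-8 assay, with a stated time of 4 days (on this read-out lower numbers stand for stronger inhibition and higher numbers for weaker inhibition), compound 1 gives 3160 nM. Compound 2 `Oc1ccc(-c2cc(-c3cccc(O)c3)nc(-c3cccc(O)c3)c2)cc1` keeps one 4-hydroxyphenyl group and carries two 3-hydroxyphenyl groups, and in this assay compound 2 gives 1760 nM. Going by the values given here, compound 2 shows the lower of the two numbers, yet its only neighbour is compound 1 and the gap between them lies within the scatter, so no order between the two can be claimed.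

Compound 3 `Oc1ccc(-c2cc(-c3ccc(O)cc3)nc(-c3cccc(O)c3)c2)cc1` is not yet measured. It differs from compound 2 in one place: 4-hydroxyphenyl in place of 3-hydroxyphenyl on an aromatic carbon. Among the compounds with values here, no measured pair isolates this change, so compound 3 can only be placed by its two neighbours, of which compound 1 gives 3160 nM and compound 2 gives 1760 nM. Compound 3 is expected to fall between them, with a step from compound 2 of a 1.3-fold higher number from compound 2 to compound 3 (0.12 log units; within the scatter), none beyond the scatter. In this assay compound 3 is estimated at 2300 nM, within a range from 1000 nM to 5000 nM.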

Compound 3, half-maximal inhibitory concentration: 5800 nM
For compound 3 the middle estimate is 2.5-fold (0.40 log units) below the measured one; the measured number lies above the stated range.
By their numbers in this assay, from the lowest: compounds 2, 1 and 3 (each within the scatter of the next, the first and the last beyond it).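

In this assay, going by these compounds alone, placing 4-hydroxyphenyl instead of 3-hydroxyphenyl on the aromatic carbon next to the ring nitrogen gives a 3.3-fold higher number from compound 2 to compound 3 (0.52 log units; beyond the scatter) and so yields the first step in this set beyond the scatter, showing that moving one hydroxyl within this group can register even though the atoms and the counted donors and acceptors stay the same. The same exchange read in the other direction, with 3-hydroxyphenyl in place of 4-hydroxyphenyl, gives a 1.8-fold higher number from compound 1 to compound 3 (0.26 log units; within the scatter) and stays within the scatter, so the change at this position is readable only in the pair where the other group at the equivalent position is 3-hydroxyphenyl, and it cannot be read where that group is 4-hydroxyphenyl. Nothing available explains why the two pairs differ.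

Going by these compounds, these two pairs cover only the hydroxyl moved around a phenyl ring, so it remains open how the position would respond to a methoxy group, an amine or a carboxylic acid in its place. The 4-hydroxyphenyl group that all three compounds share also stays unchanged, which leaves its contribution to the read-out unknown.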